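The compounds below may be only part of what the source reports. "The series", "measured", "known", "first", "only" and "open" are said of these compounds alone.

Compound 1 `CN(C)Cc1ccc2nc(NC(=O)N/N=C/c3cn(Cc4ccccc4Cl)c4ccccc34)sc2c1` and compound 2 `CN(C)Cc1ccc2nc(NC(=O)N/N=C/c3cn(Cc4ccc(Cl)cc4Cl)c4ccccc34)sc2c1` share one core and differ at a single spot. In a functional assay on NCI-H460 cells (Homo sapiens) for cytotoxicity, read by MTT assay, with a stated time of 72 h (a higher number here means a weaker inhibitor, a lower number a stronger inhibitor), compound 1 gives 1600 nM, and compound 2 gives 950 nM. The change between them, (chloro in place of hydrogen on an aromatic carbon), made a step of a 1.7-fold lower number from compound 1 to compound 2 (0.23 log units; within the scatter). Compound 3 `CC1CCN(Cc2ccc3nc(NC(=O)N/N=C/c4cn(Cc5ccccc5)c5ccccc45)sc3c2)CC1` is built on a different core; how its core differs from the core of compound 1 is not broken down here. In this assay compound 3 gives 1910 nM, a value lying within the scatter of those of compound 1 and compound 2. Compound 4 `CC1CCN(Cc2ccc3nc(NC(=O)N/N=C/c4cn(Cc5ccc(Cl)cc5)c5ccccc45)sc3c2)CC1` has not yet been measured. It differs from compound 3 by chloro in place of hydrogen on an aromatic carbon. Among the compounds with values here, this is the same kind of change as the one between compound 1 and compound 2, but not the same: in that pair the entering chloro is also meta to a chloro group, whereas here no second chloro is present. Because the earlier change gave only a 1.7-fold lower number from compound 1 to compound 2 (0.23 log units; within the scatter), a similarly small step is expected here, a 1.5-fold lower number from compound 3 to compound 4 (0.17 log units; within the scatter). Compound 4 is therefore estimated at 1300 nM, with a likely range from 600 nM to 3000 nM.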

Compound 4, half-maximal inhibitory concentration: 400 nM
Compound 4: the middle estimate sits 3.3-fold (0.51 log units) above what was measured; the measured number lies below the stated range.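

In this assay, turning the benzyl group into a 4-chlorobenzyl group gave a 4.8-fold lower number from compound 3 to compound 4 (0.68 log units; beyond the scatter), and this step does not match the earlier one on the core of compound 1: the same change on two cores in this assay, a 1.7-fold lower number (0.23 log units; within the scatter) from compound 1 to compound 2 and a 4.8-fold lower number (0.68 log units; beyond the scatter) from compound 3 to compound 4, 2.8-fold (0.45 log units) apart, beyond the scatter of two such steps

Both steps run toward a lower number, so the direction of the change carried over between these two pairs, while its size did not. Two pairs cannot show why the sizes differ, as they differ both in the core and in the ring that receives the chloro, which already carries a chloro group in compound 1 but none in compound 3.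

The compounds shown leave open how a fluoro, methoxy or trifluoromethyl group would read in place of this chloro in this assay. They also leave open what a lone 4-chlorobenzyl group would do on the core of compound 1, the comparison that would separate the effect of the core from that of the first chloro.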